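One More Methyl: Ethyl to Isopropyl in Compound 3

The source may hold more compounds than are shown below. What is called first, only, known or untested is meant among the compounds shown, and "the series" means these compounds.

For the measured compounds named here, in a functional assay on NCI-H1581 cells (Homo sapiens) for antiproliferative activity, read by CCK-8 assay, with a stated time of 72 h (a lower number here means a stronger inhibitor, a higher number a weaker inhibitor), compound 1 `COc1cc(OC)c(Cl)c(-c2ccc3c(NC(=O)c4ccc(N5CCN(C)CC5)cc4)n[nH]c3n2)c1Cl` gives 1.7 nM and compound 2 `CCN1CCN(c2ccc(C(=O)Nc3n[nH]c4nc(-c5c(Cl)c(OC)cc(OC)c5Cl)ccc34)cc2)CC1` gives 0.7 nM, the lower of the two numbers so far. Compound 3 `COc1cc(OC)c(Cl)c(-c2ccc3c(NC(=O)c4ccc(N5CCN(C(C)C)CC5)cc4)n[nH]c3n2)c1Cl` is still unmeasured. It differs from compound 2 by methyl in place of hydrogen on a saturated chain carbon bound to an amine nitrogen in a ring and a saturated chain carbon, with methyl in place of hydrogen on a saturated chain carbon bound to an amine nitrogen in a ring and a saturated chain carbon, so that ethyl becomes isopropyl. Going by the values given here, one measured step bears on this change: a 2.4-fold lower number from compound 1 to compound 2 (0.39 log units; beyond the scatter), a modest gain from a similar methyl addition. Among the compounds with values here, a single step sets no trend, so no step clearly beyond the scatter is expected here, and the direction is uncertain. The expected outcome is a 1.3-fold higher number from compound 2 to compound 3 (0.11 log units; within the scatter). For compound 3 the estimated value is 0.9 nM, with an expected range of 0.3 nM to 2.8 nM.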

Compound 3, half-maximal inhibitory concentration: 1.4 nM
Estimate against measurement, compound 3: 1.6-fold (0.19 log units) below; the measured number falls inside the stated range.
By their numbers in this assay, from the lowest: compounds 2, 3 and 1 (each within the scatter of the next, the first and the last beyond it).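

In this assay the further methyl on this chain carbon gives a 2.0-fold higher number from compound 2 to compound 3 (0.30 log units; within the scatter), so the change from 4-ethylpiperazin-1-yl to 4-isopropylpiperazin-1-yl reads as neither a gain nor a loss. Against the methyl group, isopropyl gives a 1.2-fold lower number from compound 1 to compound 3 (0.08 log units; within the scatter), so the one step beyond the scatter, a 2.4-fold lower number from compound 1 to compound 2 (0.39 log units; beyond the scatter), is not carried further by this branched group, and the ethyl group remains the only change on this amine nitrogen in the ring with a step beyond the scatter. Nothing available offers an explanation for this result.

As far as these compounds go, what remains open is how a longer chain, such as propyl, or a cyclopropyl ring would read on the same nitrogen. Equally open, from the compounds shown here alone, is whether a hydroxyethyl chain or a plain hydrogen there would keep the number in this region.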